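A few compounds are considered here, and "the series" means these few. Any claim that something is new, unique, unknown or untested is made for them only; others in the source may bear on it.

In a physicochemical assay for solubility, in phosphate buffer, with a stated time of 24 h, at pH 7.4, tested at 100 uM (a higher number here means a more soluble compound, a lower number a less soluble compound), three compounds with a shared core differ only in the group on a sulfonyl sulfur. Compound 1 `CC(C)n1cc(S(=O)(=O)c2ccc(CNC(=O)N3Cc4ccncc4C3)cc2)cn1` gives 192000 nM, compound 2 `O=C(NCc1ccc(S(=O)(=O)C2CCN(C3COC3)CC2)cc1)N1Cc2ccncc2C1` gives 121000 nM, and compound 3 `O=C(NCc1ccc(S(=O)(=O)N2CCOCC2)cc1)N1Cc2ccncc2C1` gives 59000 nM, the lowest of the three. Compound 4 `O=C(NCc1ccc(S(=O)(=O)N2CCC[C@H](O)C2)cc1)N1Cc2ccncc2C1` has 3-hydroxypiperidin-1-yl in place of morpholin-4-yl at that sulfur: 3-hydroxypiperidin-1-yl in place of morpholin-4-yl on a sulfonyl sulfur. Three measured steps change the same place. Two are modest, a 3.3-fold lower number from compound 1 to compound 3 (0.51 log units; beyond the scatter) and a 2.1-fold lower number from compound 2 to compound 3 (0.31 log units; beyond the scatter), while a 1.6-fold lower number from compound 1 to compound 2 (0.20 log units; within the scatter) stays within the scatter. None involves 3-hydroxypiperidin-1-yl, so no step beyond the scatter is expected in this assay, though a higher number is the likelier direction. The expected change is a 1.4-fold higher number from compound 3 to compound 4 (0.16 log units; within the scatter). Compound 4 is estimated at 85000 nM, with an expected range of 42000 nM to 170000 nM.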

Compound 4, solubility: 215000 nM
Compound 4: middle estimate off by 2.5-fold (0.40 log units), on the low side; the whole stated range lies below it.
By their numbers in this assay, from the lowest: compound 3; then compounds 2, 1 and 4 (each within the scatter of the next).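

In this assay, 3-hydroxypiperidin-1-yl in place of morpholin-4-yl on a sulfonyl sulfur gives a step beyond the scatter (a 3.6-fold higher number from compound 3 to compound 4 (0.56 log units; beyond the scatter)). With a 1.8-fold higher number from compound 2 to compound 4 (0.25 log units; within the scatter) and a 1.1-fold higher number from compound 1 to compound 4 (0.05 log units; within the scatter) both within the scatter, compound 1, compound 2 and compound 4 cannot be told apart despite their different groups, and only compound 3 stands apart. Nothing given here explains the step. Open, on these data alone, is whether the hydroxyl accounts for the step, which plain piperidin-1-yl would test. Also open, as far as these compounds go, is whether the opposite stereocentre or 4-hydroxypiperidin-1-yl behaves alike.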